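A few compounds are considered here, and "the series" means these few. Any claim that something is new, unique, unknown or untested is made for them only; others in the source may bear on it.

Series values in a toxicity assay on THP-1 cells (Homo sapiens) for cytotoxicity, read by MTT assay, with a stated time of 72 h; on this read-out higher numbers stand for an effect only at larger amounts of compound and lower numbers for an effect already at smaller amounts:
Compound 1 `Cc1ccc(/C=N/NC(N)=S)c2ccccc12` gives 32000 nM.
Compound 2 `NC(=S)N/N=C/c1ccc(F)c2ccccc12` gives 39000 nM.
Compound 3 `CCOc1ccc(/C=N/NC(N)=S)c2ccccc12` gives > 200000 nM, which is a limit of this assay and not a number.

Compound 3 thus stands at the top of the series, known only as a limit (the limit of > 200000 nM in this assay, at which 1 of the 3 values shown sits). Compound 4 `CCCCOc1ccc(/C=N/NC(N)=S)c2ccccc12` continues from it by ethyl in place of hydrogen on a saturated chain carbon, two bonds along the chain from an oxygen on an aromatic ring. Two measured steps lead into compound 3 and bear on this: an at least 6.2-fold higher number from compound 1 to compound 3 (0.79 log units; beyond the scatter) and an at least 5.1-fold higher number from compound 2 to compound 3 (0.70 log units; beyond the scatter). As far as these compounds go, both are at least modest and in the same direction, and both end at the limit, so their true size is unknown. The step from compound 1 to compound 2 is small: a 1.2-fold higher number from compound 1 to compound 2 (0.09 log units; within the scatter). Among the compounds with values here, no measured step lengthens a chain on the oxygen, so the change from ethoxy to butoxy has no direct precedent here. Given that compound 3 already sits at the limit, the expectation for compound 4 in this assay is a step of about a number no higher from compound 3 to compound 4 (the limit leaves the size open), that is, no shift beyond the scatter, with the result most probably again reported as a limit. Compound 4 is therefore estimated at 200000 nM, with a range from 100000 nM to 400000 nM.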

Compound 4, half-maximal effective concentration: > 200000 nM
Compound 4 ended at the assay's limit; the forecaster's own chance of this, stated with the estimate: 70%; the middle value sits exactly at the limit.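

In this assay compound 4 gives > 200000 nM, which is a limit of the assay and not a number, so the step from ethoxy to butoxy cannot be read. The two steps that can be read are an at least 6.2-fold higher number from compound 1 to compound 4 (0.79 log units; beyond the scatter) and an at least 5.1-fold higher number from compound 2 to compound 4 (0.70 log units; beyond the scatter), both beyond the scatter and both of unknown true size. Ethoxy therefore no longer stands alone at the limit: lengthening the chain on the oxygen to butoxy brings no return to a readable value, and compound 3 and compound 4 now share that limit: the limit of > 200000 nM in this assay, at which 2 of the 4 values shown sit.

As far as these compounds go, how far compound 3 and compound 4 lie past the limit stays unknown, so no order between ethoxy and butoxy can be drawn. Also open, from the compounds shown here alone, is whether methoxy, a longer chain such as hexyloxy, or an amine in place of the alkoxy group would stay at the limit or return to the range of compound 1 and compound 2.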